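Fused bicyclic series: aryl variation at the phenyl position

This account rests on a few compounds, and the source may have more. Where it says the series, first, only, none or still open, it means among the compounds named here.

Measured compounds:
compound 1 `C[C@H](Nc1ncnc2[nH]cnc12)c1cc2ccc(F)cn2c(=O)c1-c1ccccc1`, 94% in an ADME assay on microsomes from liver (Mus musculus), read by LC-MS, using NADPH, with a stated time of 30 min, tested at 1 uM; a lower number here means that less of the compound is left, a higher number that more of the compound is left
compound 2 `C[C@H](Nc1nc(N)nc(N)c1C#N)c1cc2ccc(F)cn2c(=O)c1-c1ccccc1`, 42%
compound 3 `Cc1nc(N)c(C#N)c(N[C@@H](C)c2cc3ccc(F)cn3c(=O)c2-c2ccccc2)n1`, "not determined" (no result reported)

Compound 2 stands lowest of the two numbers; compound 1 is the nearest, and the step of a number 52 percentage points lower from compound 1 to compound 2 (beyond the scatter) lies beyond the scatter. That step, however, changes the group on the amine nitrogen, not the aryl group. Compound 4 `Cc1cc(F)cc(-c2c([C@H](C)Nc3nc(N)nc(N)c3C#N)cc3ccc(F)cn3c2=O)c1` differs from compound 2 by 3-fluoro-5-methylphenyl in place of phenyl on an aromatic carbon. Going by the values given here, no measured step touches this position, so nothing here sets a direction; the estimate rests on compound 2 alone. Compound 4 is therefore expected to stay near its parent, with no change at the digits printed from compound 2 to compound 4 (within the scatter) as the expected step, none beyond the scatter. The expected value for compound 4 is 42%, in the range 18% to 68%.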

Compound 4, percent of the compound remaining: < 1%
Compound 4 ended at the assay's limit (the forecaster's own chance of this, stated with the estimate: 2%); middle value at least 41 percentage points away from the limit.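

In this assay, 3-fluoro-5-methylphenyl in place of phenyl gives a number at least 41 percentage points lower from compound 2 to compound 4 (beyond the scatter), so the aryl position affects the percent remaining, and not only the group on the amine nitrogen does. Compound 4 sits at a limit of the assay, not at a number: the limit of < 1% in this assay, at which 1 of the 4 values shown sits.

The fluorine and the methyl enter together, and the compounds shown do not separate them, as 3-fluorophenyl or 3-methylphenyl alone would. From the compounds shown here alone, whether the same aryl change has a similar effect with the amine-nitrogen group of compound 1 also stays open.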